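Swapping Fluorosulfonyloxy for Trifluoromethyl on the Shared Core

The compounds below may be only part of what the source reports. "The series", "measured", "known", "first", "only" and "open" are said of these compounds alone.

Compound 3 `CC1(C)C=C(n2ccccc2=O)c2cc(OS(=O)(=O)F)ccc2O1` is the most potent of the three compounds measured in a functional assay (aorta) with Rattus norvegicus as the target (a higher number here means a more potent compound, by a factor of ten per unit of this negative logarithm, a lower number a less potent compound), where compound 3 gives 7.95. Compound 1 `COc1ccc2c(c1)C(n1ccccc1=O)=CC(C)(C)O2` gives 6.55 and compound 2 `CC1(C)C=C(n2ccccc2=O)c2cc(C(=N)NO)ccc2O1` gives 5.99. Compound 4 `CC1(C)C=C(n2ccccc2=O)c2cc(C(F)(F)F)ccc2O1` differs from compound 3 in one place: trifluoromethyl in place of (fluorosulfonyl)oxy on an aromatic carbon. Two measured steps lead into compound 3, and both are large: a number 1.40 log units higher from compound 1 to compound 3 (beyond the scatter) and a number 1.96 log units higher from compound 2 to compound 3 (beyond the scatter). Within the data shown here, neither of these steps involves trifluoromethyl, so they show only that a change at this position can shift potency strongly, without saying where trifluoromethyl will land. Among the measured compounds shown here, with no direct precedent, the step is expected to be a number 0.55 log units lower from compound 3 to compound 4 (beyond the scatter), a modest loss with wide uncertainty. Compound 4 is estimated at 7.4, within a range from 6.6 to 8.1.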

Compound 4, logarithm of the reciprocal of the active concentration, log(1/C): 7.61
The estimate for compound 4 lay 0.21 log units below the measured number; the range from low to high includes it.
By their numbers in this assay, from the lowest: compound 2; then compound 1; then compound 4; then compound 3.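

In this assay, moving from (fluorosulfonyl)oxy to trifluoromethyl at this aromatic carbon costs only a modest part of the potency, with a number 0.34 log units lower from compound 3 to compound 4 (beyond the scatter) as the result. Trifluoromethyl still stands well clear of the other two groups, with a number 1.62 log units higher from compound 2 to compound 4 (beyond the scatter) and also a number 1.06 log units higher from compound 1 to compound 4 (beyond the scatter) on the change from methoxy. A high number at this position is thus reached with a group that counts no hydrogen-bond donors or acceptors. From the compounds shown here alone, whether an amine or a carboxylic acid here would stay near compound 4 or fall toward compound 2 remains open. Nothing at hand explains the gaps between these groups.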